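This account rests on a few compounds, and the source may have more. Where it says the series, first, only, none or still open, it means among the compounds named here.

Of the compounds shown here, two have been measured: compound 1 `CC(C(=O)NCc1ccc(C(F)(F)F)nc1N1CCC(C(F)(F)F)CC1)c1ccc(NS(C)(=O)=O)c(F)c1`, which in a functional assay on CHO-K1 cells for antagonist activity at transient receptor potential cation channel subfamily V member 1 (Homo sapiens), read by FLIPR (a lower number here means a stronger inhibitor, a higher number a weaker inhibitor), gives 31 nM, and compound 2 `CCCCOC1CCN(c2nc(C(F)(F)F)ccc2CNC(=O)C(C)c2ccc(NS(C)(=O)=O)c(F)c2)CC1`, which in this assay gives 28.2 nM.

Compound 2 holds the lowest of the two numbers, yet the step of a 1.1-fold lower number from compound 1 to compound 2 (0.04 log units; within the scatter) lies within the scatter, so the two compounds stand level in this assay. Compound 3 `CC(C(=O)NCc1ccc(C(F)(F)F)nc1N1CCCCCC1)c1ccc(NS(C)(=O)=O)c(F)c1` differs from compound 2 by a group of 7 heavy atoms (6 carbon, 1 nitrogen; one seven-membered non-aromatic ring with 1 hetero atom) in place of a group of 11 heavy atoms (9 carbon, 1 nitrogen, 1 oxygen; one six-membered non-aromatic ring with 1 hetero atom), on an aromatic carbon. For the measured compounds named here, only one measured step bears on this position: a 1.1-fold lower number from compound 1 to compound 2 (0.04 log units; within the scatter), which exchanged one substituent for another on the saturated ring and left the number essentially unchanged. Going by the values given here, no measured step removes the ring substituent altogether or alters the ring size, so the present change goes beyond what the data cover. A modest weakening is expected rather than a large one. The estimate for compound 3 in this assay is 70 nM, with a range from 20 nM to 250 nM. This expected step corresponds to a 2.5-fold higher number from compound 2 to compound 3 (0.39 log units; beyond the scatter).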

Compound 3, half-maximal inhibitory concentration: 25.1 nM
Compound 3: the middle estimate sits 2.8-fold (0.45 log units) above what was measured; low and high end bracket the measured number.
By their numbers in this assay, from the lowest: compounds 3, 2 and 1 (each within the scatter of the next).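

In this assay, the group on the aromatic carbon next to the ring nitrogen can change in ring size and lose its ring substituent with no reading beyond the scatter: the steps are a 1.1-fold lower number from compound 2 to compound 3 (0.05 log units; within the scatter) and a 1.2-fold lower number from compound 1 to compound 3 (0.09 log units; within the scatter). The unsubstituted seven-membered azepan-1-yl therefore stands level with both substituted six-membered rings, so among these three compounds neither the butoxy nor the trifluoromethyl substituent is needed to hold the number at this level. No supporting measurement accounts for this tolerance.

The compounds shown leave open whether a smaller pyrrolidin-1-yl ring or an open-chain diethylamino group would stand level as well. They also leave open whether a carboxylic acid or a primary amine on the saturated ring would do so.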